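Lengthening the sulfur side chain of an inactive compound

The compounds below may be only part of what the source reports. "The series", "measured", "known", "first", "only" and "open" are said of these compounds alone.

In a functional assay on HCT-116 cells (Homo sapiens) for inhibition, read by MTT assay, with a stated time of 48 h (on this read-out higher numbers stand for weaker inhibition and lower numbers for stronger inhibition), compound 1 (`COc1ccc(-n2c(S)nnc2-c2cc(OC)c(OC)c(OC)c2)cc1`) gives > 60000 nM, which is a limit of the assay and not a number. Compound 2 (`COc1ccc(-n2c(SC)nnc2-c2cc(OC)c(OC)c(OC)c2)cc1`) gives > 60000 nM, again only a limit, so no exact number marks its place.

Compound 3 (`COc1ccc(C(=O)CSc2nnc(-c3cc(OC)c(OC)c(OC)c3)n2-c2ccc(OC)cc2)cc1`) keeps the shared core and alters the group on the sulfur. The change is (4-methoxyphenyl)carbonyl in place of hydrogen on a saturated chain carbon bound to a sulfur, which turns methyl into ((4-methoxyphenyl)carbonyl)methyl.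

Within the data shown here, the only measured step is a step that the two limits leave unreadable from compound 1 to compound 2, made by methyl in place of hydrogen on a sulfur. It offers no size to carry over because of the limit of > 60000 nM in this assay, at which 2 of the 2 values shown sit. The new change is also much larger than that one.

With compound 2 at > 60000 nM, a limit, any readable number in this assay would mean stronger inhibition, so a modest step in that direction is expected, although remaining at the limit is quite possible. The estimated change is an at least 2.4-fold lower number from compound 2 to compound 3 (0.38 log units; beyond the scatter). For compound 3 the expected value is 25000 nM, with an estimated range from 4000 nM to 60000 nM.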

Compound 3, half-maximal inhibitory concentration: > 60000 nM
Compound 3: no number, only a limit; the forecaster's own chance of this, stated with the estimate: 45%; middle value at least 2.4-fold (0.38 log units) away from the limit.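

In this assay compound 3 gives > 60000 nM, which is a limit of the assay and not a number. The steps to compound 3 from compound 1 and compound 2 therefore cannot be read, because all three compounds sit at the same limit: the limit of > 60000 nM in this assay, at which 3 of the 3 values shown sit.

The compounds shown leave open whether any group on the sulfur gives a readable number.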